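Aryl versus arylalkyl substituent on the shared core

The source may report more compounds than this note shows. Statements on the series, on what has been measured and on what is new or still open speak of the compounds shown alone.

Measured so far:
- compound 1, `C=C(Br)C(=O)Nc1cccc(-c2cn3nc(Cc4ccc(Cl)cc4)sc3n2)c1`: 3300 nM
- compound 2, `C=C(Br)C(=O)Nc1cccc(-c2cn3nc(-c4cccc(OC)c4)sc3n2)c1`: 1200 nM
- compound 3, `C=C(Br)C(=O)Nc1cccc(-c2cn3nc(CCc4ccccc4)sc3n2)c1`: 4200 nM

In a functional assay on CCRF-CEM cells (Homo sapiens) for inhibition, read by cell counting, with a stated time of 3 days (a higher number here means a weaker inhibitor, a lower number a stronger inhibitor), compound 3 gives the highest of the three numbers. Its gap to compound 1 is within the scatter, so the two cannot be ordered; its gap to compound 2 is beyond the scatter, shown by a 3.5-fold higher number from compound 2 to compound 3 (0.54 log units; beyond the scatter). Compound 4, `C=C(Br)C(=O)Nc1cccc(-c2cn3nc(-c4ccc(OC)cc4)sc3n2)c1`, is not yet measured. It differs from compound 3 by 4-methoxyphenyl in place of phenethyl on an aromatic carbon.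

Among the compounds with values here, the step that bears on this change is the one from compound 2 to compound 3: a 3.5-fold higher number from compound 2 to compound 3 (0.54 log units; beyond the scatter), a modest move toward weaker inhibition when a directly attached methoxyphenyl is replaced by phenethyl. Within the data shown here, compound 4 reverses that kind of change, returning to a directly attached methoxyphenyl, though with the methoxy at a different position, for which no measured step exists. A modest move toward a lower number is therefore expected, a 2.8-fold lower number from compound 3 to compound 4 (0.45 log units; beyond the scatter), roughly undoing the step to compound 3. Compound 4 is estimated at 1500 nM in this assay, within a range of 600 nM to 4000 nM.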

Compound 4, half-maximal inhibitory concentration: 1200 nM
Compound 4: middle estimate off by 1.3-fold (0.10 log units), on the high side; the measured number falls inside the stated range.
By their numbers in this assay, from the lowest: compounds 2 and 4 (each within the scatter of the next); then compounds 1 and 3 (each within the scatter of the next).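

In this assay, the methoxy position on the directly attached phenyl makes no readable difference at this aromatic carbon: 4-methoxyphenyl in place of 3-methoxyphenyl gives no separation (no change at the digits printed from compound 2 to compound 4 (within the scatter)). The gain over the arylalkyl groups therefore holds for both methoxyphenyl isomers, with 4-methoxyphenyl also beyond the scatter against phenethyl (a 3.5-fold lower number from compound 3 to compound 4 (0.54 log units; beyond the scatter)) and against 4-chlorobenzyl (a 2.8-fold lower number from compound 1 to compound 4 (0.44 log units; beyond the scatter)). Nothing available explains these differences.

Still open, on these data alone, is whether the methoxy itself contributes, or whether an unsubstituted phenyl, or a phenyl carrying an amine or a carboxylic acid, would stay level with compound 2 and compound 4. Also open, as far as these compounds go, is how a longer chain carrying the phenyl would compare with phenethyl.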